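Swapping Dimethylamino for Diethylamino on a Shared Core

The source may report more compounds than this note shows. Statements on the series, on what has been measured and on what is new or still open speak of the compounds shown alone.

Of the compounds shown here, three have been measured in a functional assay on MCF7 cells (Homo sapiens) for antiproliferative activity, read by CCK-8 assay, with a stated time of 24 h; on this read-out higher numbers stand for weaker inhibition and lower numbers for stronger inhibition. Compound 1 `C/C(=N\NC(=O)Nc1nc2ccc(CN(C)C)cc2s1)c1ccccn1` carries a dimethylamino group on a saturated chain carbon bound to an aromatic carbon. In this assay compound 1 gives > 40000 nM, which is a limit of the assay and not a number. Compound 3 `CCN(CC)Cc1ccc2nc(NC(=O)N/N=C(\C)c3ccccn3)sc2c1` differs from compound 1 in one place: diethylamino in place of dimethylamino on a saturated chain carbon bound to an aromatic carbon. In this assay compound 3 also gives a limit, > 40000 nM. The measured step that the two limits leave unreadable from compound 1 to compound 3 therefore cannot be read, since both of its ends are limits. Compound 2 `CN(C)Cc1ccc2nc(NC(=O)NN=C(c3ccccn3)c3ccccn3)sc2c1` has a different core from compound 1; the difference between the two cores is not broken down here. In this assay compound 2 likewise gives a limit, > 40000 nM. All three measured values thus sit at the limit of > 40000 nM in this assay, at which 3 of the 3 values shown sit.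

Compound 4 `CCN(CC)Cc1ccc2nc(NC(=O)NN=C(c3ccccn3)c3ccccn3)sc2c1` has not yet been measured. It differs from compound 2 in one place: diethylamino in place of dimethylamino on a saturated chain carbon bound to an aromatic carbon. Among the compounds with values here, this is the same change, at the same place, as the one from compound 1 to compound 3. Within the data shown here, because a step that the two limits leave unreadable from compound 1 to compound 3 stays unreadable with both of its values at the limit of > 40000 nM in this assay, at which 3 of the 3 values shown sit, the only guide is that the same change left the readout unchanged at the limit once already. For compound 4 the expected step is a step that the limit leaves unreadable from compound 2 to compound 4. Compound 4 is therefore estimated to give about 60000 nM in this assay, most likely between 30000 nM and 150000 nM, and most probably again only as a limit rather than a number.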

Compound 4, half-maximal inhibitory concentration: > 40000 nM
Compound 4 gave a limit, no number; the forecaster's own chance of this, stated with the estimate: 90%; the middle value does not contradict the limit.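

In this assay compound 4 gives > 40000 nM, a limit of the assay and not a number. The step from compound 2 to compound 4 therefore cannot be read, because both ends sit at a limit: the limit of > 40000 nM in this assay, at which 4 of the 4 values shown sit.

The compounds shown leave open whether diethylamino in place of dimethylamino changes the result in this assay at all, since none of them yet gives a number there.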